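Three Limits and One Expectation in a Cell Assay

This account rests on a few compounds, and the source may have more. Where it says the series, first, only, none or still open, it means among the compounds named here.

Compound 1 `OC[C@H]1O[C@@H](n2cnc3c(NCc4cccc(C(F)(F)F)c4)ncnc32)[C@H](O)[C@@H]1O`: in a functional assay on MCF cells (Homo sapiens) for antiproliferative activity, with a stated time of 72 h (a higher number here means a weaker inhibitor, a lower number a stronger inhibitor), compound 1 gives > 166000 nM, which is a limit of the assay.
Compound 2 `OC[C@H]1O[C@@H](n2cnc3c(NCc4ccc(C(F)(F)F)cc4)ncnc32)[C@H](O)[C@@H]1O`: in this assay compound 2 gives > 166000 nM, again a limit.
Compound 3 `OC[C@H]1O[C@@H](n2cnc3c(NCc4cccc(OC(F)(F)F)c4)ncnc32)[C@H](O)[C@@H]1O`: in this assay compound 3 gives > 166000 nM, also a limit.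

All three sit at the limit of > 166000 nM in this assay, at which 3 of the 3 values shown sit. Compound 2 differs from compound 1 by 4-(trifluoromethyl)phenyl in place of 3-(trifluoromethyl)phenyl on a saturated chain carbon bound to a nitrogen on an aromatic ring, and the step that the two limits leave unreadable from compound 1 to compound 2. Compound 3 differs from compound 1 by trifluoromethoxy in place of trifluoromethyl on an aromatic carbon, and the step that the two limits leave unreadable from compound 1 to compound 3.

Compound 4 `OC[C@H]1O[C@@H](n2cnc3c(NCc4ccc(OC(F)(F)F)cc4)ncnc32)[C@H](O)[C@@H]1O` has not been measured. It differs from compound 2 by trifluoromethoxy in place of trifluoromethyl on an aromatic carbon, the same kind of change as that from compound 1 to compound 3, though here the place is para to a large group rather than meta to a large group. Resting only on the limit shown for compound 2, compound 4 is expected to give about 200000 nM in this assay, most likely again as a limit. That corresponds to an expected step that the limit leaves unreadable from compound 2 to compound 4.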

Compound 4, half-maximal inhibitory concentration: > 166000 nM
Compound 4: a limit, no number (the forecaster's own chance of this, stated with the estimate: 90%); the middle value lies beyond the limit too.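

Compound 4, like compound 2, gives only a limit, so no step between them can be read: the limit of > 166000 nM in this assay, at which 4 of the 4 values shown sit.

The compounds shown leave open how trifluoromethoxy and trifluoromethyl compare in this assay, and whether any of the four has a measurable potency there.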